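Working notes: from compound 1 to compound 3

The compounds below may be only part of what the source reports. "The series", "measured", "known", "first", "only" and "open" are said of these compounds alone.

Measured so far in a functional assay on A549 cells (Homo sapiens) for inhibition, read by sulforhodamine B assay, with a stated time of 48 h; on this read-out lower numbers stand for stronger inhibition and higher numbers for weaker inhibition
- compound 1 `COc1ccc(C(OCc2ccccc2)c2cccc3ccccc23)c(OC)c1OC` gives 13500 nM
- compound 2 `CCOC(=O)/C=C/CO/N=C(/c1ccc(OC)c(OC)c1OC)c1cccc2ccccc12` gives 14000 nM

Compound 1 stands level with compound 2, the two values lying within the scatter of each other. Compound 3 `COc1ccc(C(c2ccccc2O)c2cccc3ccccc23)c(OC)c1OC` departs from compound 1 by 2-hydroxyphenyl in place of benzyloxy on a saturated chain carbon bound to two aromatic carbons and so carries 2-hydroxyphenyl in place of benzyloxy on a saturated chain carbon bound to two aromatic carbons. For the measured compounds named here, no measured step in this assay sizes this change, so only a moderate shift towards a lower number is expected. Going by the values given here, the expected change is a 2.3-fold lower number from compound 1 to compound 3 (0.35 log units; beyond the scatter) and this rests on no measured pair. Compound 3 is estimated at 6000 nM with an expected range of 1500 nM to 25000 nM in this read-out.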

Compound 3, half-maximal inhibitory concentration: 13600 nM
Compound 3: the middle estimate sits 2.3-fold (0.36 log units) below what was measured, and the stated range covers the measured number.
By their numbers in this assay, from the lowest: compounds 1, 3 and 2 (each within the scatter of the next).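

In this assay, for the compounds shown here, the only measured step at the saturated chain carbon bound to two aromatic carbons is a 1.0-fold higher number from compound 1 to compound 3 (0.00 log units; within the scatter), so 2-hydroxyphenyl in place of benzyloxy leaves the number level. Here, entry of the hydrogen-bond donor counted on 2-hydroxyphenyl comes with no shift beyond the scatter. Nothing at hand accounts for this result.

Going by these compounds, whether an amine or a carboxylic acid at this carbon would give a number beyond the scatter from compound 1 stays open. So does the effect of a longer chain there.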